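A few compounds are considered here, and "the series" means these few. Any claim that something is new, unique, unknown or untested is made for them only; others in the source may bear on it.

Among the compounds with values here, compound 1 `CCCCCN(C)/N=N/c1nc[nH]c1C(N)=O` stands highest of the two numbers measured so far: in a functional assay on L1210 cells (Mus musculus) for antiproliferative activity (a lower number here means a less potent compound, a higher number a more potent compound, by a factor of ten per unit of this negative logarithm), compound 1 gives 3.58. Its nearest neighbour is compound 2 `CCCCCCCCN(C)/N=N/c1nc[nH]c1C(N)=O`, which in this assay gives 3. The step of a number 0.58 log units lower from compound 1 to compound 2 (beyond the scatter) is a modest drop that comes with propyl in place of hydrogen on a saturated chain carbon, five bonds along the chain from an amine nitrogen, a longer chain. Compound 3 `CC(C)CN(C)/N=N/c1nc[nH]c1C(N)=O` has not yet been measured. Within the data shown here, it differs from compound 1 by isopropyl in place of butyl on a saturated chain carbon bound to an amine nitrogen, a chain made shorter and branched, the opposite direction to the only measured change. Among the measured compounds shown here, that one step, of size a number 0.58 log units lower from compound 1 to compound 2 (beyond the scatter), is the sole guide, and it points the other way, so compound 3 is expected to sit near compound 1, with an expected step of a number 0.12 log units higher from compound 1 to compound 3 (within the scatter), within the scatter. Compound 3 is estimated at 3.7, in the range 3.2 to 4.2.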

Compound 3, logarithm of the reciprocal of the active concentration, log(1/C): 3.51
Beside the measured number, compound 3's estimate is 0.19 log units above it; the measured number falls inside the stated range.
By their numbers in this assay, from the lowest: compound 2; then compounds 3 and 1 (each within the scatter of the next).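

The earlier compounds shown here showed only that a longer chain lowers the number. Putting isopropyl in place of butyl on a saturated chain carbon bound to an amine nitrogen gives a number 0.07 log units lower from compound 1 to compound 3 (within the scatter) in this assay, so a shorter, branched chain at this place shows no readable difference from the pentyl of compound 1. No measurement at hand explains why the numbers of these two compounds stay together.

Because shortening and branching arrive together in this one change, the compounds shown cannot say what either does alone, and branching might hide an effect of the shorter length. From the compounds shown here alone, how the number responds to a smaller group such as ethyl, or to a chain ending in a carboxylic acid, remains open.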